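This account rests on a few compounds, and the source may have more. Where it says the series, first, only, none or still open, it means among the compounds named here.

Compound 1 `O=C(NC1CCCCC1)Oc1cccc(-c2cccc(F)c2)c1`: 96.6 nM
Compound 2 `O=C(NC1CCCCC1)Oc1cccc(-c2cccc(-c3ccccc3)c2)c1`: 565 nM
Compound 3 `O=C(NC1CCCCC1)Oc1cccc(-c2cccc([N+](=O)[O-])c2)c1`: 49.6 nM

In an assay on cell membranes for binding affinity to Fatty-acid amide hydrolase 1 (Rattus norvegicus) (on this read-out lower numbers stand for stronger inhibition and higher numbers for weaker inhibition), compound 3 gives the lowest number of the three. Compound 1 stands nearest, and the step of a 1.9-fold lower number from compound 1 to compound 3 (0.29 log units; within the scatter) is within the scatter, so these two cannot be ranked against each other. Compound 2 stands furthest, and the step of an 11-fold lower number from compound 2 to compound 3 (1.06 log units; beyond the scatter) is large. Compound 4 `NS(=O)(=O)c1cccc(-c2cccc(OC(=O)NC3CCCCC3)c2)c1` differs from compound 3 in one place: sulfamoyl in place of nitro on an aromatic carbon. Within the data shown here, no measured step exchanges a nitro group for a sulfamoyl group, so the guide is indirect: the exchange a 1.9-fold lower number from compound 1 to compound 3 (0.29 log units; within the scatter) stayed within the scatter, and only the phenyl exchange a 5.8-fold higher number from compound 1 to compound 2 (0.77 log units; beyond the scatter) moved the number clearly. The expected step of a 1.4-fold higher number from compound 3 to compound 4 (0.15 log units; within the scatter) is therefore small, leaning toward a slightly higher number. Compound 4 is estimated at 70 nM, with a range from 20 nM to 250 nM.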

Compound 4, half-maximal inhibitory concentration: 26.5 nM
Estimate against measurement, compound 4: 2.6-fold (0.42 log units) above; the measured number falls inside the stated range.
By their numbers in this assay, from the lowest: compounds 4, 3 and 1 (each within the scatter of the next, the first and the last beyond it); then compound 2.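

In this assay, swapping nitro for sulfamoyl, which adds a sulfur and a hydrogen-bond donor, gives no readable change at this position (a 1.9-fold lower number from compound 3 to compound 4 (0.27 log units; within the scatter)). Sulfamoyl is also the first group here to separate clearly from fluoro (a 3.6-fold lower number from compound 1 to compound 4 (0.56 log units; beyond the scatter)), something nitro did not do, and its gap to phenyl is large (a 21-fold lower number from compound 2 to compound 4 (1.33 log units; beyond the scatter)). Nothing available explains these steps. Going by these compounds, it remains open how an amine, a carboxylic acid or a methyl sulfone would read at this position. On these data alone, whether sulfamoyl would behave the same at another position on the ring also remains open.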